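Butyl-chain analogue of the shared quinazoline-free core series

The source may hold more compounds than are shown below. What is called first, only, known or untested is meant among the compounds shown, and "the series" means these compounds.

Notes on the series. Compound 1 `CN(C)CCCNc1nc(NCc2ccco2)c2ccccc2n1` carries a 3-(dimethylamino)propyl chain on the amine of the shared core; in a functional assay on A375P cells (Homo sapiens) for cytotoxicity, read by MTT assay, with a stated time of 2 days (a higher number here means a weaker inhibitor, a lower number a stronger inhibitor), compound 1 stands as "not determined" (no result reported), so it cannot be placed on the numbers. For the measured compounds named here, the two measured members carry an arylpiperazine on a four-carbon chain instead: compound 2 `Clc1cccc(N2CCN(CCCCNc3nc(NCc4ccco4)c4ccccc4n3)CC2)c1Cl` gives 3750 nM in this assay, and compound 3 `Cc1cccc(N2CCN(CCCCNc3nc(NCc4ccco4)c4cc(F)ccc4n3)CC2)c1C`, which also carries a fluorine on the core, gives 3280 nM. These two values lie within the usual scatter of each other, so nothing can be said of an order between them.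

Compound 4 `CCCCNc1nc(NCc2ccco2)c2ccccc2n1` differs from compound 1 in one place, (methyl in place of dimethylamino on a saturated chain carbon, three bonds along the chain from a nitrogen on an aromatic ring). With no value for compound 1, no step size in this assay can be read from this pair; the only anchors are the two measured compounds, both weak, both carrying a larger substituent on the chain than compound 4 does. The expectation for compound 4 is therefore drawn from those two values alone and is held loosely, with a wide range and a real chance that the assay reports only a limit. The estimated value for compound 4 in this assay is 6000 nM, within a range from 1500 nM to 25000 nM.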

Compound 4, half-maximal inhibitory concentration: 9200 nM
Estimate against measurement, compound 4: 1.5-fold (0.19 log units) below, within the range that was stated.
By their numbers in this assay, from the lowest: compounds 3 and 2 (each within the scatter of the next); then compound 4.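

In this assay, for the compounds shown here, compound 1 stands as "not determined" (no result reported), so no step from it to compound 4 can be read. The compounds shown leave open what the change from 3-(dimethylamino)propyl to butyl does to the read-out, and what the core fluorine of compound 3 contributes on its own. No supporting evidence bears on these values.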